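The compounds below may be only part of what the source reports. "The series", "measured", "known", "first", "only" and "open" are said of these compounds alone.

Working notes on the acetophenone ether series. Three compounds have been run in an assay on isolated protein for inhibition of Amine oxidase [flavin-containing] B (Homo sapiens), read by Amplex Red, with a stated time of 15 min; on this read-out lower numbers stand for stronger inhibition and higher numbers for weaker inhibition. Compound 1 `CC(=O)c1ccc(OCc2ccccc2C)cc1` gives 77.1 nM, compound 2 `CC(=O)c1cccc(OCc2ccc(F)cc2)c1` gives 86.4 nM and compound 3 `CC(=O)c1cccc(OCc2cccc(Br)c2)c1` gives 96.3 nM; compound 2 holds the second highest of the three numbers, but its gaps to compound 1 and to compound 3 both lie within the scatter, so the three read as one cluster. Compound 4 `CC(=O)c1cccc(OCc2ccc(C(F)(F)F)cc2)c1` has not been measured. Relative to compound 2 it carries trifluoromethyl in place of fluoro on an aromatic carbon. Going by the values given here, no measured pair shows this change, so the step from compound 2 to compound 4 in this assay is expected to stay small, at most a modest rise, and the estimate of a 1.3-fold higher number from compound 2 to compound 4 (0.10 log units; within the scatter) reflects that. Compound 4 is expected to give 110 nM, within 50 nM to 250 nM.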

Compound 4, half-maximal inhibitory concentration: 43.2 nM
For compound 4 the middle estimate is 2.5-fold (0.41 log units) above the measured one; measured number below the stated range.
By their numbers in this assay, from the lowest: compounds 4, 1, 2 and 3 (each within the scatter of the next, the first and the last beyond it).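

Going by these compounds alone, the first pair at this position gives a 2.0-fold lower number from compound 2 to compound 4 (0.30 log units; within the scatter) in this assay and shows that trifluoromethyl, with 4 heavy atoms, can take the place of fluoro on this aromatic carbon, para to a large group, without a step beyond the scatter. No evidence on hand accounts for this step.

Going by these compounds, whether an amine, a carboxylic acid or a longer chain on the same carbon would stay within the scatter of compound 2 remains open. On these data alone, the effect of trifluoromethyl at other places on this ring also remains open.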